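Aryl variation at the branched urea terminus of the series

A few compounds are considered here, and "the series" means these few. Any claim that something is new, unique, unknown or untested is made for them only; others in the source may bear on it.

Measured compounds:
compound 1 `Cc1nc(N)sc1CCCN/C(N)=N/C(=O)NC(C)c1cccc(F)c1` gives 26.3 nM in a functional assay on Right cardiac atrium for agonist activity at histamine H2 receptor (Cavia porcellus), with a stated time of 30 min, in the presence of a further agent that is not named here; on this read-out lower numbers stand for an effect already at smaller amounts and higher numbers for an effect only at larger amounts of compound.
compound 2 `CCCCCNC(=O)/N=C(\N)NCCCc1sc(N)nc1C` gives 5.75 nM in this assay.
compound 3 `CCCCCCNC(=O)/N=C(\N)NCCCc1sc(N)nc1C` gives 15.9 nM in this assay.

Compound 1 stands highest of the three numbers in this assay. Its nearest neighbour is compound 3, whose number is lower by a margin within the scatter; the gap to compound 2 is larger and beyond the scatter. Among the measured compounds shown here, the only single-point step among measured compounds is a 2.8-fold higher number from compound 2 to compound 3 (0.44 log units; beyond the scatter), which concerns the length of an alkyl chain and not an aromatic group.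

Compound 4 `Cc1ccc(C(C)NC(=O)/N=C(\N)NCCCc2sc(N)nc2C)cc1` is not yet measured. It differs from compound 1 by 4-methylphenyl in place of 3-fluorophenyl on a saturated chain carbon bound to an amide-type nitrogen and a saturated chain carbon. For the measured compounds named here, no measured pair in this set probes a change on the aromatic ring, so nothing here bears directly on the step from compound 1 to compound 4. The alkyl step between compound 2 and compound 3 shows that a modest change at the urea terminus moves the number by only a modest amount, and an exchange of one unsubstituted six-membered aromatic ring for another of the same size is expected to do no more.

The expected outcome is therefore a 1.0-fold lower number from compound 1 to compound 4 (0.00 log units; within the scatter), a change not beyond the scatter. For compound 4 the estimate is 26 nM, with a range from 10 nM to 70 nM.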

Compound 4, half-maximal effective concentration: 22.4 nM
Beside the measured number, compound 4's estimate is 1.2-fold (0.06 log units) above it; measured number inside the range.
By their numbers in this assay, from the lowest: compound 2; then compounds 3, 4 and 1 (each within the scatter of the next).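

In this assay, among the compounds shown here, the exchange of 3-fluorophenyl for 4-methylphenyl on a saturated chain carbon bound to an amide-type nitrogen and a saturated chain carbon gives a 1.2-fold lower number from compound 1 to compound 4 (0.07 log units; within the scatter), the first reading of a change to the aromatic group at this position, and on this read-out the two groups cannot be told apart. This position thus takes a change of both the ring substituent and its place on the ring without a shift beyond the scatter, whereas the alkyl step at the urea terminus, a 2.8-fold higher number from compound 2 to compound 3 (0.44 log units; beyond the scatter), lies beyond it. No measurement of any property of these groups accompanies this result, and the data offer no explanation for it.

Still open, going by these compounds, is whether unsubstituted phenyl, 4-fluorophenyl or 3-methylphenyl in the same place would also read close to compound 1, as this single pair alters the substituent and its ring position together. Equally open, on these data alone, is whether a ring carrying an amine or a carboxylic acid, or a pyridyl group in place of the phenyl ring, would keep the number in this range.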